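The source may hold more compounds than are shown below. What is called first, only, known or untested is meant among the compounds shown, and "the series" means these compounds.

Working notes on the series, read in an ADME assay on WI-38 cells (Homo sapiens) for cytotoxicity, read by sulforhodamine B assay, with a stated time of 24 h; on this read-out lower numbers stand for stronger inhibition and higher numbers for weaker inhibition. Compound 1 `CC(=O)N/N=C1\C(=O)Nc2ccc(S(=O)(=O)N3CCOCC3)cc21` gives 325000 nM, compound 2 `O=C1Nc2ccc(S(=O)(=O)N3CCOCC3)cc2/C1=N/NC(=O)c1ccccc1` gives 295000 nM and compound 3 `CC(=O)c1cccc(/N=C2\C(=O)Nc3ccc(S(=O)(=O)N4CCOCC4)cc32)c1` gives 177000 nM. Compound 3 stands level with the other two, with steps of a 1.8-fold lower number from compound 1 to compound 3 (0.26 log units; within the scatter) and a 1.7-fold lower number from compound 2 to compound 3 (0.22 log units; within the scatter).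

The next compound is compound 4 `O=C1Nc2ccc(S(=O)(=O)N3CCOCC3)cc2/C1=N/c1ccc(Cl)cc1`, which carries 4-chlorophenyl in place of 3-acetylphenyl on a double-bonded nitrogen. The two steps above bear most directly on it, since each exchanges the group on that nitrogen, and neither leaves the scatter. The remaining step, a 1.1-fold lower number from compound 1 to compound 2 (0.04 log units; within the scatter), is also small. For the measured compounds named here, no measured compound carries 4-chlorophenyl, so this expectation rests on a narrow base of three compounds. No step beyond the scatter is expected in this assay, and no direction is favoured. The expected step is a 1.1-fold higher number from compound 3 to compound 4 (0.05 log units; within the scatter). Compound 4 is estimated at 200000 nM, with an expected range of 95000 nM to 400000 nM.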

Compound 4, half-maximal inhibitory concentration: 468000 nM
Beside the measured number, compound 4's estimate is 2.3-fold (0.37 log units) below it; measured number outside the range, above it.
By their numbers in this assay, from the lowest: compounds 3, 2, 1 and 4 (each within the scatter of the next, the first and the last beyond it).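

In this assay, for the compounds shown here, the group on the double-bonded nitrogen gives a step beyond the scatter for the first time in these compounds: a 2.6-fold higher number from compound 3 to compound 4 (0.42 log units; beyond the scatter), a modest change with 4-chlorophenyl in place of 3-acetylphenyl. The other two exchanges at this position stay within the scatter, with a 1.6-fold higher number from compound 2 to compound 4 (0.20 log units; within the scatter) for 4-chlorophenyl in place of benzamido and a 1.4-fold higher number from compound 1 to compound 4 (0.16 log units; within the scatter) for 4-chlorophenyl in place of acetamido, so only the two substituted phenyl groups are separated here. Nothing measured on these compounds accounts for that separation.

From the compounds shown here alone, the step compares 3-acetylphenyl and 4-chlorophenyl as whole groups, so the separate shares of the acetyl and the chlorine remain open. Also open, going by these compounds, is how unsubstituted phenyl, or a phenyl carrying an amine or a carboxylic acid, would read on that nitrogen.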